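This account rests on a few compounds, and the source may have more. Where it says the series, first, only, none or still open, it means among the compounds named here.

Compound 1, drawn as `C=CCn1c(=O)/c(=C\c2cccc(F)c2)[nH]c(=O)/c1=C\c1ccccc1OC`, was tested in a functional assay on Huh-7 cells (Homo sapiens) for cytotoxicity, read by CCK-8 assay, with a stated time of 72 h (on this read-out higher numbers stand for weaker inhibition and lower numbers for stronger inhibition), where compound 1 gives 27200 nM. Among the measured compounds shown here, that is the only number in this small set: the one other measured compound, compound 2, `C=CCn1c(=O)/c(=C\c2cccc(Br)c2)[nH]c(=O)/c1=C\c1cccc(Br)c1`, is reported in this assay simply as "not active" (no number reported), with no figure attached, so compound 1 cannot be ranked against it and stands alone as the single point of reference, and a weak one at that. Compound 3, `C=CCn1c(=O)/c(=C\c2ccccc2F)[nH]c(=O)/c1=C\c1ccccc1OC`, has not yet been measured. It differs from compound 1 in one place: 2-fluorophenyl in place of 3-fluorophenyl on a double-bonded chain carbon bound to an aromatic carbon. The two compounds hold the same atoms, joined differently. For the measured compounds named here, no step between measured compounds is available to show what such a move does in this setting. Given that, the expectation is a change no larger than the usual scatter, in no particular direction, so the expected step is a 1.1-fold higher number from compound 1 to compound 3 (0.04 log units; within the scatter). Compound 3 is therefore estimated to give about 30000 nM in this assay, with a likely range from 10000 nM to 90000 nM. There is also a real chance that compound 3 is reported only as not active, as compound 2 was.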

Compound 3, half-maximal inhibitory concentration: 31300 nM
Beside the measured number, compound 3's estimate is 1.0-fold (0.02 log units) below it; the measured number falls inside the stated range.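

In this assay, putting 2-fluorophenyl in place of 3-fluorophenyl on a double-bonded chain carbon bound to an aromatic carbon gives a 1.2-fold higher number from compound 1 to compound 3 (0.06 log units; within the scatter) and so leaves the two compounds indistinguishable on this read-out. Among the compounds shown here, this is the first measured step in the set, and it shows that, for this one pair, exchanging these two fluorophenyl groups at this place produces no difference that can be separated from ordinary variation between repeated measurements. No measurement is available that would explain this result.

A single step within the scatter says little about how much this place matters in general, since both groups have the same atoms and a larger change there could behave quite differently. From the compounds shown here alone, how the number would respond if the fluorophenyl group gave way to a group carrying an amine or a carboxylic acid remains open, as does whether the same exchange would give a similar result on a compound with a different group at the other end of the shared core.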